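Alkoxy chain variation on the shared core, antiproliferative read-out

This account rests on a few compounds, and the source may have more. Where it says the series, first, only, none or still open, it means among the compounds named here.

Measured compounds in a functional assay on A2780/DX3 cells (Homo sapiens) for antiproliferative activity, read by MTT assay, with a stated time of 3 days; on this read-out higher numbers stand for weaker inhibition and lower numbers for stronger inhibition:
compound 1 `CCCCOC1(c2ccc(Br)cc2)SC=C(C)n2c1noc2=O` gives 78000 nM.
compound 2 `CCCCCOC1(c2ccc(Cl)cc2)SC=C(C)n2c1noc2=O` gives > 100000 nM, which is a limit of the assay, not a number.
compound 3 `CC/C=C\COC1(c2ccc(Cl)cc2)SC=C(C)n2c1noc2=O` gives 103000 nM.

Compound 3 holds the highest of the two numbers; compound 1 sits within the scatter of it. Among the compounds with values here, the only single-point step, a step that the limit leaves unreadable from compound 2 to compound 3, cannot be read because of the limit of > 100000 nM in this assay, at which 1 of the 3 values shown sits.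

Compound 4 `CCCCOC1(c2ccc(Cl)cc2)SC=C(C)n2c1noc2=O` differs from compound 3 by propyl in place of but-1-en-1-yl on a saturated chain carbon bound to an oxygen on a saturated carbon. Within the data shown here, no measured step covers this change directly; compound 1 carries the same saturated chain on a different halogen and reads close to compound 3, while compound 2 stopped at the limit. Compound 4 is therefore expected to stay in the same weak range, with a real chance of a limit. The expected step of a 1.1-fold lower number from compound 3 to compound 4 (0.06 log units; within the scatter) is within the scatter. The estimate for compound 4 is 90000 nM, range 45000 nM to 200000 nM.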

Compound 4, half-maximal inhibitory concentration: 49000 nM
The estimate for compound 4 lay 1.8-fold (0.26 log units) above the measured number; measured number inside the range.
By their numbers in this assay, from the lowest: compounds 4, 1 and 3 (each within the scatter of the next, the first and the last beyond it).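

In this assay, within the data shown here, the first readable step at this position is modest but lies beyond the scatter, with propyl in place of but-1-en-1-yl: a 2.1-fold lower number from compound 3 to compound 4 (0.32 log units; beyond the scatter). Chloro in place of bromo on an aromatic carbon stays within the scatter: a 1.6-fold lower number from compound 1 to compound 4 (0.20 log units; within the scatter). The value of compound 2 is a limit, so shortening the chain gives only a floor, an at least 2.0-fold lower number from compound 2 to compound 4 (0.30 log units; that floor lies within the scatter), and the true size stays unknown: the limit of > 100000 nM in this assay, at which 1 of the 4 values shown sits.

Still open, on these data alone, is how an ethoxy group would read on the shared core. As far as these compounds go, a chain ending in an amine or a carboxylic acid also remains open.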